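The compounds below may be only part of what the source reports. "The series", "measured", "known", "first", "only" and "open" are said of these compounds alone.

In a functional assay on HT-29 cells (Homo sapiens) for inhibition, read by luminescence and CellTiter-Glo, with a stated time of 24 h (a higher number here means that more compound is needed for the effect, a lower number that less compound is needed), compound 3 `CN1C(=S)[C@@H](NC(=O)c2nc(Cc3ccccc3)n(CC3CCOC3)n2)COc2ccccc21` gives 4420 nM. This lies within the scatter of compound 1 `CC(C)CCn1nc(C(=O)N[C@H]2COc3ccccc3N(C)C2=S)nc1Cc1ccccc1` at 3640 nM and of compound 2 `CN1C(=S)[C@@H](NC(=O)c2nc(Cc3ccccc3)n(CCCC#N)n2)COc2ccccc21` at 2400 nM. Compound 4 `CN1C(=S)[C@@H](NC(=O)c2nc(Cc3ccccc3)n(-c3ncccn3)n2)COc2ccccc21` has pyrimidin-2-yl in place of (oxolan-3-yl)methyl on an aromatic nitrogen. The closest evidence comes from exchanges on this same nitrogen substituent: a 1.5-fold lower number from compound 1 to compound 2 (0.18 log units; within the scatter), a 1.2-fold higher number from compound 1 to compound 3 (0.08 log units; within the scatter) and a 1.8-fold higher number from compound 2 to compound 3 (0.27 log units; within the scatter). All three stay within the scatter, but none brings an aromatic ring onto that nitrogen, so the data give no direction. No step beyond the scatter is therefore expected in this assay, although the uncertainty is wide. The expected step is a 1.3-fold lower number from compound 3 to compound 4 (0.10 log units; within the scatter). The estimate for compound 4 is 3500 nM, with an expected range of 1000 nM to 11000 nM.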

Compound 4, half-maximal effective concentration: 3970 nM
For compound 4 the middle estimate is 1.1-fold (0.05 log units) below the measured one; the range from low to high includes it.
By their numbers in this assay, from the lowest: compounds 2, 1, 4 and 3 (each within the scatter of the next).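

In this assay an aromatic ring set directly on this nitrogen gives steps no larger than those among the saturated chains: a 1.1-fold lower number from compound 3 to compound 4 (0.05 log units; within the scatter) and a 1.7-fold higher number from compound 2 to compound 4 (0.22 log units; within the scatter) and a 1.1-fold higher number from compound 1 to compound 4 (0.04 log units; within the scatter) all stay small. Across these four compounds, pyrimidin-2-yl, (oxolan-3-yl)methyl, 3-cyanopropyl and isopentyl cannot be told apart at this position. Nothing measured here offers an explanation. On these data alone, whether an amine or a carboxylic acid on this nitrogen would shift the number remains open, and so does whether a plain phenyl ring would behave like pyrimidin-2-yl.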